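Urea to amide on a pyrazole-linked diaryl scaffold

A few compounds are considered here, and "the series" means these few. Any claim that something is new, unique, unknown or untested is made for them only; others in the source may bear on it.

Compound 2 `COc1cc(Cl)cc(-c2nn(-c3cccc(NC(=O)Nc4cccc(C(F)(F)F)c4)c3)cc2-c2ccncc2)c1` stands at the top of the two numbers measured in a functional assay on A498 cells (Homo sapiens) for inhibition, read by sulforhodamine B assay, with a stated time of 48 h, tested at 100 uM (on this read-out higher numbers stand for a weaker effect at the one concentration tested and lower numbers for a stronger effect), where compound 2 gives -6%. Going by the values given here, its neighbour compound 1 `COc1cc(Cl)cc(-c2nn(-c3cccc(NC(=O)Nc4ccc(Cl)c(C(F)(F)F)c4)c3)cc2-c2ccncc2)c1` gives -70% in this assay, and the only measured step, a number 64 percentage points higher from compound 1 to compound 2 (beyond the scatter), runs between them. Compound 3 `COc1cc(Cl)cc(-c2nn(-c3cccc(NC(=O)c4cccc(C(F)(F)F)c4)c3)cc2-c2ccncc2)c1` differs from compound 2 in a different place: 3-(trifluoromethyl)phenyl in place of (3-(trifluoromethyl)phenyl)amino on a carbonyl carbon. The carbonyl carbon keeps its amide-type nitrogen as the other neighbour, while the group that leaves carries one hydrogen-bond donor and the group that enters carries none. Among the compounds with values here, no measured step touches this part of the molecule, so the step of compound 1 to compound 2 does not bear on it, and the size and direction of the change are open. On that basis compound 3 is expected to give about -10% in this assay, between -50% and 20%, which would mean an estimated step of a number 4 percentage points lower from compound 2 to compound 3 (within the scatter).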

Compound 3, a percentage reported as activity, at one concentration (the size of the read-out at that concentration, not a potency): 59%
Compound 3: the middle estimate sits 69 percentage points below what was measured, outside the stated range (above it).
By their numbers in this assay, from the lowest: compound 1; then compound 2; then compound 3.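

In this assay, going by these compounds alone, putting 3-(trifluoromethyl)phenyl in place of (3-(trifluoromethyl)phenyl)amino on the carbonyl carbon gives a number 65 percentage points higher from compound 2 to compound 3 (beyond the scatter), so this place, which no earlier step touched, also strongly affects the read-out, and the change goes towards a weaker effect. Measured against the chlorinated urea, the change in the same place gives a number 129 percentage points higher from compound 1 to compound 3 (beyond the scatter), which means that the stronger effect seen with the (4-chloro-3-(trifluoromethyl)phenyl)amino group does not survive this replacement. Nothing available explains why removing the nitrogen-hydrogen unit has this outcome.

Going by these compounds, it remains open whether the chloro substituent would strengthen the effect on the amide as it does on the urea. A carbamate, with oxygen in place of the nitrogen, or an N-methyl urea would help separate the role of the amide hydrogen from that of the linker length.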